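The source may report more compounds than this note shows. Statements on the series, on what has been measured and on what is new or still open speak of the compounds shown alone.

Measured so far in an ADME assay on MT4 cells (Homo sapiens) for cytotoxicity, read by MTT assay; a lower number here means that less compound is tolerated, a higher number that more compound is tolerated:
- compound 1, `S=C(Nc1cccc(Cl)c1)OCCc1ccccn1`, gives 47000 nM
- compound 2, `O=[N+]([O-])c1cccc(NC(=S)OCCc2ccccn2)c1`, gives 100000 nM
- compound 3, `CCc1ccc(NC(=S)OCCc2ccccn2)cc1`, gives 44000 nM

Among these three numbers compound 3 sits at the low end: its value lies within the scatter of that of compound 1, while the value of compound 2 is higher by a margin beyond the scatter. The only step shown between two measured compounds is a 2.1-fold higher number from compound 1 to compound 2 (0.33 log units; beyond the scatter), a swap of one small group for another on the aromatic ring of the shared core.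

Compound 4, `Fc1ccc(NC(=S)OCCc2ccccn2)cc1`, differs from compound 3 in one place: fluoro in place of ethyl on an aromatic carbon. This too is a swap of one small substituent on the same ring, so the measured step bears on it, and it was modest. A change of similar or smaller size is therefore expected in this assay, with no clear direction, and quite possibly nothing beyond the scatter. Compound 4 is expected to give about 50000 nM, within 25000 nM to 100000 nM. This corresponds to an expected step of a 1.1-fold higher number from compound 3 to compound 4 (0.06 log units; within the scatter).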

Compound 4, half-maximal cytotoxic concentration: > 100000 nM
Compound 4: only a limit was reported; the forecaster's own chance of this, stated with the estimate: 15%; at least 2.0-fold (0.30 log units) between middle value and limit.
By their numbers in this assay, from the lowest: compounds 3 and 1 (each within the scatter of the next); then compound 2.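

In this assay, putting fluoro in place of ethyl on an aromatic carbon para to a large group gives an at least 2.2-fold higher number from compound 3 to compound 4 (0.35 log units; beyond the scatter), so this place on the ring can respond to a swap of one small group for another. Among the compounds shown here, the earlier compounds did not show this, as their only step, a 2.1-fold higher number from compound 1 to compound 2 (0.33 log units; beyond the scatter), involved chloro and nitro and did not touch this place. The reading for compound 4 is a limit of the assay and not a number: the limit of > 100000 nM in this assay, at which 1 of the 4 values shown sits.

The compounds shown leave open whether the change follows from the loss of ethyl or the arrival of fluoro. Methyl, a longer chain such as propyl, an amine or a carboxylic acid at this same place would help to separate the two.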